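This account rests on a few compounds, and the source may have more. Where it says the series, first, only, none or still open, it means among the compounds named here.

Compounds measured in an ADME assay on L02 cells (Homo sapiens) for cytotoxicity, read by MTT assay; a lower number here means a stronger inhibitor, a higher number a weaker inhibitor:
compound 1 `C#CCOc1cc(/C=C/C(=O)c2ccc(OC)c3c2OC(C)(C)C=C3)ccc1OC` — > 10000 nM
compound 2 `CCCCC(=O)Oc1cc(/C=C/C(=O)c2ccc(OC)c3c2OC(C)(C)C=C3)ccc1OC` — > 10000 nM
compound 3 `COc1ccc(/C=C/C(=O)c2ccc(OC)c3c2OC(C)(C)C=C3)cc1CS(C)(=O)=O` — > 10000 nM

Each of these three values is a limit of the assay, not a number. Compound 1 sits at the limit > 10000 nM. Compound 2 likewise sits only at the limit > 10000 nM. Compound 3 also reaches no more than the limit > 10000 nM. Because of this, (the limit of > 10000 nM in this assay, at which 3 of the 3 values shown sit), none of the three steps can be read: a step that the two limits leave unreadable from compound 1 to compound 2, a step that the two limits leave unreadable from compound 1 to compound 3 and a step that the two limits leave unreadable from compound 2 to compound 3 all remain of unreadable size.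

The step under consideration leads from compound 2 to compound 4 `COc1ccc(/C=C/C(=O)c2ccc(OC)c3c2OC(C)(C)C=C3)cc1OS(=O)(=O)c1ccc(C)cc1`, in which a (4-methylphenyl)sulfonyl stands in place of butylcarbonyl on an oxygen on an aromatic ring ((4-methylphenyl)sulfonyl in place of butylcarbonyl on an oxygen on an aromatic ring). Among the measured compounds shown here, the measured steps bear on it only in that every change at this position so far has left the value at the limit; they give no readable size in either direction. Compound 4 is therefore expected to remain at or beyond that limit, estimated at 15000 nM with a range from 6000 nM to 40000 nM. The step this estimate implies is a step that the limit leaves unreadable from compound 2 to compound 4, expected to lie within the scatter.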

Compound 4, half-maximal inhibitory concentration: > 10000 nM
Compound 4 ended at the assay's limit (the forecaster's own chance of this, stated with the estimate: 85%); the middle value does not contradict the limit.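

In this assay compound 4 gives only a limit, > 10000 nM, so its steps to compound 1, compound 2 and compound 3 cannot be read: the limit of > 10000 nM in this assay, at which 4 of the 4 values shown sit. The compounds shown leave open how these four compounds compare with one another, since none has a value beyond a limit.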